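Moving the chlorine around the phenoxy ring of compound 2

The source may report more compounds than this note shows. Statements on the series, on what has been measured and on what is new or still open speak of the compounds shown alone.

Of the compounds shown here, two have been measured in a functional assay for inhibition of sodium/hydrogen exchanger (Oryctolagus cuniculus); on this read-out lower numbers stand for stronger inhibition and higher numbers for weaker inhibition. Compound 1 `CCSc1cc(C)c(C(=O)N=C(N)N)cc1S(C)(=O)=O` gives 5.9 nM. For the measured compounds named here, compound 2 `Cc1cc(Oc2cccc(Cl)c2)c(S(C)(=O)=O)cc1C(=O)N=C(N)N` gives 21 nM, the higher of the two numbers; the only measured step, a 3.6-fold higher number from compound 1 to compound 2 (0.55 log units; beyond the scatter), replaces the ethylsulfanyl group with a 3-chlorophenoxy group. Compound 3 `Cc1cc(Oc2ccc(Cl)cc2)c(S(C)(=O)=O)cc1C(=O)N=C(N)N` has not been measured. It differs from compound 2 by 4-chlorophenyl in place of 3-chlorophenyl on an oxygen on an aromatic ring, so the two share every atom and differ only in where the chlorine sits on the phenoxy ring. Going by the values given here, no measured step bears directly on this kind of change: the one step on record swaps a whole group rather than shifting a substituent. Without a comparable precedent, the step of a 1.1-fold lower number from compound 2 to compound 3 (0.02 log units; within the scatter) is expected to stay within the scatter, in no particular direction. Compound 3 is therefore estimated at 20 nM, with a range from 8 nM to 55 nM.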

Compound 3, half-maximal inhibitory concentration: 13 nM
The estimate for compound 3 lay 1.5-fold (0.19 log units) above the measured number; the range from low to high includes it.
By their numbers in this assay, from the lowest: compound 1; then compounds 3 and 2 (each within the scatter of the next).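

In this assay the move from 3-chlorophenyl to 4-chlorophenyl on the oxygen gives a 1.6-fold lower number from compound 2 to compound 3 (0.21 log units; within the scatter), so the two placements of the chlorine cannot be told apart on this read-out. For the compounds shown here, the exchange of ethylsulfanyl for a chlorophenoxy group, until now seen only with 3-chlorophenoxy, also holds with 4-chlorophenoxy: a 2.2-fold higher number from compound 1 to compound 3 (0.34 log units; beyond the scatter), a modest step that stays beyond the scatter, so both chlorophenoxy compounds give higher numbers than compound 1. No supporting evidence accounts for either step.

The compounds shown leave open whether a plain phenoxy group, with no chlorine, or 4-fluorophenoxy would give a number close to those of compound 2 and compound 3. They also leave open how a methoxy group or a longer sulfanyl chain would compare with ethylsulfanyl at this aromatic carbon.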